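This account rests on a few compounds, and the source may have more. Where it says the series, first, only, none or still open, it means among the compounds named here.

Compound 1, `Nc1ccc2cccc(OC3CCC3)c2n1`: in an assay on cells with melanin-concentrating hormone receptor 1 (Homo sapiens) as the target, read by radioligand binding (a higher number here means a weaker inhibitor, a lower number a stronger inhibitor), compound 1 gives only a limit, > 2000 nM.
Compound 2, `CCC(C)COc1cccc2ccc(N)nc12`: in this assay compound 2 gives 36 nM.
Compound 3, `Nc1ccc2cccc(OCCC(F)(F)F)c2n1`: in this assay compound 3 gives 722 nM.

Of the two plain numbers, compound 3 stands highest, and the step of a 20-fold higher number from compound 2 to compound 3 (1.30 log units; beyond the scatter) separates it from its nearest neighbour. Compound 4, `Nc1ccc2cccc(OCCC3CC3)c2n1`, differs from compound 3 by cyclopropyl in place of trifluoromethyl on a saturated chain carbon, two bonds along the chain from an oxygen on an aromatic ring.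

Three measured steps speak to this change. The steps of an at least 55-fold lower number from compound 1 to compound 2 (1.74 log units; beyond the scatter) and an at least 2.7-fold lower number from compound 1 to compound 3 (0.44 log units; beyond the scatter) both replaced the cyclobutyl on the oxygen with a chain and both lowered the number, the 2-methylbutyl chain far more than the 3,3,3-trifluoropropyl one. The step of a 20-fold higher number from compound 2 to compound 3 (1.30 log units; beyond the scatter) shows that putting the fluorinated group in place of an all-carbon group raised the number sharply. Compound 4 moves the other way, putting a ring of carbon only where the trifluoromethyl stood, so a lowering of the number is expected, a 4.8-fold lower number from compound 3 to compound 4 (0.68 log units; beyond the scatter). Compound 4 is therefore estimated to give about 150 nM, with a range from 40 nM to 600 nM.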

Compound 4, half-maximal inhibitory concentration: 492 nM
The estimate for compound 4 lay 3.3-fold (0.52 log units) below the measured number; measured number inside the range.
By their numbers in this assay, from the lowest: compound 2; then compounds 4 and 3 (each within the scatter of the next). At a limit, above all of these: compound 1.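

In this assay, cyclopropyl and trifluoromethyl cannot be told apart at this place on the chain, with a 1.5-fold lower number from compound 3 to compound 4 (0.17 log units; within the scatter). An end group of carbon only still leaves a wide gap to the 2-methylbutyl chain, with a 14-fold higher number from compound 2 to compound 4 (1.14 log units; beyond the scatter), so the fluorine atoms alone do not account for the higher number of compound 3. Replacing cyclobutyl with 2-cyclopropylethyl gives an at least 4.0-fold lower number from compound 1 to compound 4 (0.60 log units; beyond the scatter), though this step starts from a limit, which is what compound 1 gives rather than a plain number: the limit of > 2000 nM in this assay, at which 1 of the 4 values shown sits.

On these data alone, what sets the 2-methylbutyl chain apart remains open, including whether its branch matters or whether a straight butyl chain or a longer chain would do as well. Also open, as far as these compounds go, is how an amine or a hydroxyl group at the end of the chain would fare.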